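Benzyloxy nitroanilide amides: cyano for dichloro on the aryl

This account rests on a few compounds, and the source may have more. Where it says the series, first, only, none or still open, it means among the compounds named here.

Working notes on the series. Compound 1 `O=C(Nc1ccc([N+](=O)[O-])cc1OCc1ccccc1)C1CCCCC1` carries a cyclohexyl on the carbonyl carbon. In an assay on SK-BR-3 cells for inhibition of Aromatase (Homo sapiens) (a higher number here means a weaker inhibitor, a lower number a stronger inhibitor), compound 1 gives > 25000 nM, which is a limit of the assay and not a number. Compound 2 `O=C(Nc1ccc([N+](=O)[O-])cc1OCc1ccccc1)c1ccc(Cl)c([N+](=O)[O-])c1` and compound 3 `O=C(Nc1ccc([N+](=O)[O-])cc1OCc1ccccc1)c1ccc(Cl)c(Cl)c1` carry substituted phenyl groups on that carbonyl carbon. In this assay compound 2 gives > 25000 nM, again a limit. Compound 3 gives > 25000 nM, also a limit. Compound 3 therefore stands at the limit of > 25000 nM in this assay, at which 3 of the 3 values shown sit, where every value of the series sits. The steps a step that the two limits leave unreadable from compound 1 to compound 2, a step that the two limits leave unreadable from compound 1 to compound 3 and a step that the two limits leave unreadable from compound 2 to compound 3 have no readable size or direction.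

Compound 4 `N#Cc1ccc(C(=O)Nc2ccc([N+](=O)[O-])cc2OCc2ccccc2)cc1` differs from compound 3 by 4-cyanophenyl in place of 3,4-dichlorophenyl on a carbonyl carbon. The measured steps that bear on an aryl exchange on this carbonyl carbon are all unreadable, so no size or direction can be drawn from them. The step that the limit leaves unreadable from compound 3 to compound 4 is expected to remain unreadable against the same limit. Compound 4 is expected at 30000 nM, within 8000 nM to 100000 nM, most likely reported as a limit once more.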

Compound 4, half-maximal inhibitory concentration: > 25000 nM
Compound 4 was reported as a limit; the forecaster's own chance of this, stated with the estimate: 75%; the middle value does not contradict the limit.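

In this assay compound 4 gives > 25000 nM, which is again a limit and not a number. Its steps from compound 1, compound 2 and compound 3 therefore cannot be read: the limit of > 25000 nM in this assay, at which 4 of the 4 values shown sit. The compounds shown leave open which group on the carbonyl carbon, if any, would give a readable value.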